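Notes on the chain end group: dimethylamino to benzamido

A few compounds are considered here, and "the series" means these few. Any claim that something is new, unique, unknown or untested is made for them only; others in the source may bear on it.

Measured so far in a functional assay on MCF7 cells (Homo sapiens) for cytotoxicity, read by MTT assay, with a stated time of 72 h; on this read-out higher numbers stand for weaker inhibition and lower numbers for stronger inhibition:
compound 1 `C[C@@H](Nc1c(C(=O)NCc2ccc(F)cc2)nc(Br)c2cccnc12)c1ccccc1` gives "not determined" (no result reported)
compound 2 `NCCCNc1c(C(=O)NCc2ccc(F)cc2)nc(Br)c2cccnc12` gives 6000 nM
compound 3 `CN(C)CCCNc1c(C(=O)NCc2ccc(F)cc2)nc(Br)c2cccnc12` gives 7000 nM

Compound 3 at 7000 nM lies within the scatter of compound 2 at 6000 nM and compound 1 supplies no number to set beside them. The change to compound 4 `O=C(NCCCNc1c(C(=O)NCc2ccc(F)cc2)nc(Br)c2cccnc12)c1ccccc1` is benzamido in place of dimethylamino on a saturated chain carbon, three bonds along the chain from a nitrogen on an aromatic ring and so places benzamido where compound 3 has dimethylamino. For the measured compounds named here, one measured step bears on this chain carbon, a 1.2-fold higher number from compound 2 to compound 3 (0.07 log units; within the scatter), and it stayed within the scatter. That step exchanged amino for dimethylamino and brought in no aromatic ring, so it offers only weak guidance for benzamido. In this assay no step beyond the scatter is expected, with only a slight lean towards a lower number. The expected step is a 1.4-fold lower number from compound 3 to compound 4 (0.15 log units; within the scatter) and remains uncertain. The estimate for compound 4 is 5000 nM with 1500 nM to 20000 nM as the expected range.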

Compound 4, half-maximal inhibitory concentration: 2000 nM
Estimate against measurement, compound 4: 2.5-fold (0.40 log units) above, within the range that was stated.
By their numbers in this assay, from the lowest: compound 4; then compounds 2 and 3 (each within the scatter of the next).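

In this assay this chain carbon now shows a step beyond the scatter: benzamido in place of dimethylamino gives a 3.5-fold lower number from compound 3 to compound 4 (0.54 log units; beyond the scatter), and benzoyl in place of hydrogen on the amine nitrogen gives a 3.0-fold lower number from compound 2 to compound 4 (0.48 log units; beyond the scatter). The exchange of amino for dimethylamino, by contrast, gave only a 1.2-fold higher number from compound 2 to compound 3 (0.07 log units; within the scatter), so among these three end groups the number moves beyond the scatter only with benzamido. No supporting measurement is available to explain the shift.

The compounds shown do not separate the amide link of benzamido from its aromatic ring: acetamido would carry the first without the second, and benzylamino the second without the first. As far as these compounds go, how the number responds to a longer chain, or to a fluorine on the benzoyl ring, also remains open.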